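Lengthening the Amide Chain from Compound 3 to Compound 4

The source may hold more compounds than are shown below. What is called first, only, known or untested is meant among the compounds shown, and "the series" means these compounds.

Compound 1 `COc1cc2c(cc1OC)C(CC(N)=O)CC2` gives 30.4% in a functional assay on the whole organism (strain Wistar) for inhibition, with Rattus norvegicus as the target, read by paw edema, with stated times of 60 min and 3 h, at a dose of 100 mg/kg by the oral route; a higher number here means more inhibition at the dose given (going by the name of the read-out), a lower number less inhibition.
Compound 2 `CCN(CC)C(=O)CC1CCc2cc(OC)c(OC)cc21` gives 37.7%.
Compound 3 `CCCCCNC(=O)CC1CCc2cc(OC)c(OC)cc21` gives 37.7%.

Compound 3 stands level with compound 2, the two together the highest of the three numbers, since no change at the digits printed from compound 2 to compound 3 (within the scatter). The furthest compound is compound 1, and a number 7.3 percentage points higher from compound 1 to compound 3 (within the scatter).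

Compound 4 `CCCCCCNC(=O)CC1CCc2cc(OC)c(OC)cc21` carries one change from compound 3: methyl in place of hydrogen on a saturated chain carbon, five bonds along the chain from an amide-type nitrogen. The steps that touch the amide substituent, a number 7.3 percentage points higher from compound 1 to compound 3 (within the scatter) and no change at the digits printed from compound 2 to compound 3 (within the scatter), both stay inside the scatter, so adding one more carbon to the pentyl chain is expected to give no step beyond the scatter, a number 0.7 percentage points lower from compound 3 to compound 4 (within the scatter). Compound 4 is therefore estimated at 37%, with a range from 25% to 50%.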

Compound 4, a percentage reported as inhibition, in the whole organism at one dose (the size of the read-out at that dose, not a potency): 44.6%
Compound 4: middle estimate off by 7.6 percentage points, on the low side, and the stated range covers the measured number.
By their numbers in this assay, from the lowest: compounds 1, 2, 3 and 4 (each within the scatter of the next, the first and the last beyond it).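

In this assay, methyl on the saturated chain carbon, five bonds along the chain from the amide-type nitrogen, gives a number 6.9 percentage points higher from compound 3 to compound 4 (within the scatter), and hexylamino in place of diethylamino gives a number 6.9 percentage points higher from compound 2 to compound 4 (within the scatter), so neither change separates these compounds. Hexyl in place of hydrogen on the amide-type nitrogen gives a number 14.2 percentage points higher from compound 1 to compound 4 (beyond the scatter), the only step among the compounds shown that lies beyond the scatter, though a modest one. No evidence is available that accounts for this step. The compounds shown leave open whether a longer chain such as octyl would go further, and whether an amine or a carboxylic acid at the chain end would keep this level of inhibition.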